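A Second Trifluoromethyl on a Sulfone-Linked Aryl Ring

A few compounds are considered here, and "the series" means these few. Any claim that something is new, unique, unknown or untested is made for them only; others in the source may bear on it.

Measured compounds:
compound 1 `CC(O)(COc1ccc(C#N)cc1)C(=O)Nc1ccc(S(F)(F)(F)(F)F)cc1` with 100000 nM
compound 2 `CC(O)(COc1ccc(C#N)cc1C(F)(F)F)C(=O)Nc1ccc(S(F)(F)(F)(F)F)cc1` with 100000 nM
compound 3 `CC(O)(CS(=O)(=O)c1cccc(C(F)(F)F)c1)C(=O)Nc1ccc(S(F)(F)(F)(F)F)cc1` with 21000 nM

All three were tested in a functional assay on LNCaP cells (Homo sapiens) for antiproliferative activity, read by propidium iodide staining, with a stated time of 96 h; a lower number here means a stronger inhibitor, a higher number a weaker inhibitor. Compound 1 and compound 2 share one core, and the difference between them is trifluoromethyl in place of hydrogen on an aromatic carbon. The step it made, no change at the digits printed from compound 1 to compound 2 (within the scatter), shows that the added group did nothing visible there. Compound 3 is built on a different core; how that core differs from the core of compound 1 is not broken down here. Compound 3 gives the lowest number of the three, and its gap to compound 1 and to compound 2 lies beyond the scatter.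

Compound 4 `CC(O)(CS(=O)(=O)c1cc(C(F)(F)F)cc(C(F)(F)F)c1)C(=O)Nc1ccc(S(F)(F)(F)(F)F)cc1` has not yet been measured. Relative to compound 3 the change is trifluoromethyl in place of hydrogen on an aromatic carbon. It is the same kind of change as from compound 1 to compound 2, but not the same: in compound 2 the new group sits ortho to a large group and meta to a cyano group, whereas in compound 4 it sits meta to a large group and meta to a trifluoromethyl group.

Because no change at the digits printed from compound 1 to compound 2 (within the scatter) was flat, the expected step for compound 4 is a 1.2-fold lower number from compound 3 to compound 4 (0.07 log units; within the scatter), a small one. That rests on a single earlier example, so the range is kept wide. Compound 4 is therefore estimated at 18000 nM, expected to fall between 6000 nM and 60000 nM in this assay.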

Compound 4, half-maximal inhibitory concentration: 13300 nM
Beside the measured number, compound 4's estimate is 1.4-fold (0.13 log units) above it; measured number inside the range.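

In this assay, putting trifluoromethyl in place of hydrogen on an aromatic carbon gave a 1.6-fold lower number from compound 3 to compound 4 (0.20 log units; within the scatter), so a second trifluoromethyl on the ring of compound 3 made no change that can be told apart from ordinary assay variation. Set beside the earlier step, the change behaves alike on both cores, with neither step large enough to read as a real shift: the same change on two cores in this assay, no change at the digits printed (within the scatter) from compound 1 to compound 2 and a 1.6-fold lower number (0.20 log units; within the scatter) from compound 3 to compound 4, 1.6-fold (0.20 log units) apart, within the scatter of two such steps. Within the data shown here, this shows only that the change stayed flat in this one assay on these two pairs, even though the new group sits in different surroundings on each core and the starting values differ, with compound 1 at 100000 nM and compound 3 at 21000 nM; it does not show that the change would stay flat on any other core or in any other test.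

As far as these compounds go, it remains open whether a chlorine atom or an amine on that same aromatic carbon would give a step beyond the scatter on either core. Also open, from the compounds shown here alone, is which structural difference between compound 1 and compound 3 goes with the gap in their numbers, since these two compounds differ in more than one place.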